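Swapping chloro for methoxy on compound 3

The source may hold more compounds than are shown below. What is called first, only, known or untested is meant among the compounds shown, and "the series" means these compounds.

Measured so far in a functional assay on CCRF-CEM cells (Homo sapiens) for inhibition; on this read-out lower numbers stand for stronger inhibition and higher numbers for weaker inhibition
- Compound 1 `O=C1/C(=C/c2ccc(F)cc2)Cc2ccccc21` gives 42200 nM
- Compound 2 `Cc1cccc(/C=C2\Cc3ccccc3C2=O)c1` gives 41300 nM
- Compound 3 `O=C1/C(=C/c2ccc(Cl)cc2)CCCc2ccccc21` gives 15100 nM

Compound 3 has the lowest number of the three, and compound 1 and compound 2 both sit higher by more than the usual scatter. Compound 4 `COc1ccc(/C=C2\CCCc3ccccc3C2=O)cc1` keeps the core of compound 3 but has methoxy in place of chloro on an aromatic carbon. Among the compounds with values here, no measured pair isolates this kind of swap, so the data offer no direct guide. Only a small change is expected, within the scatter, leaning slightly towards weaker inhibition. The estimated size of this change is a 1.2-fold higher number from compound 3 to compound 4 (0.08 log units; within the scatter) in this assay on this reasoning. The estimate for compound 4 is 18000 nM with an expected range from 7000 nM to 45000 nM around it.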

Compound 4, half-maximal inhibitory concentration: 350 nM
Compound 4: the middle estimate sits 51-fold (1.71 log units) above what was measured, outside the stated range (below it).
By their numbers in this assay, from the lowest: compound 4; then compound 3; then compounds 2 and 1 (each within the scatter of the next).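

Within this assay, methoxy in place of chloro on an aromatic carbon para to a large group gives a 43-fold lower number from compound 3 to compound 4 (1.63 log units; beyond the scatter) and so shows that the group held at this position can matter greatly. Within the data shown here, the earlier compounds held no pair differing in one place, so this is the first direct reading of a single swap. Nothing measured here explains the size of this step.

From the compounds shown here alone, it remains open whether the drop is specific to methoxy, or whether ethoxy, hydroxy or a dimethylamino group at the same position would give a similar number. It is also unknown whether methoxy would produce a drop of similar size on the core of compound 1.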